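Two Ureas Barely Stabilise the Target; a Methyl Added

This account rests on a few compounds, and the source may have more. Where it says the series, first, only, none or still open, it means among the compounds named here.

Measured so far:
compound 1 `CCOc1ccc(NC(=O)Nc2cc(C(C)(C)C)nn2-c2ccccc2)cc1` — 1 degrees C
compound 2 `CC(C)(C)c1cc(NC(=O)Nc2cc(C(F)(F)F)cc(C(F)(F)F)c2)n(-c2ccccc2)n1` — 0.8 degrees C

Of the compounds shown here, two sharing a urea-linked core have been tested in an assay on isolated protein for inhibition of Ephrin type-A receptor 2 (Homo sapiens), read by thermal shift assay, tested at 10 uM; a lower number here means that the compound stabilises the target less, a higher number that the compound stabilises the target more against heat. Compound 1 gives 1 degrees C, and compound 2 gives 0.8 degrees C. In this assay compound 2 has the lower of the two numbers, but its gap to compound 1 lies within the scatter, so the two compounds cannot be told apart; both barely stabilise the target.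

Compound 3 `Cc1ccc(-n2nc(C(C)(C)C)cc2NC(=O)Nc2cc(C(F)(F)F)cc(C(F)(F)F)c2)cc1` is the next to be measured. It differs from compound 2 in one place: methyl in place of hydrogen on an aromatic carbon. For the measured compounds named here, no measured pair shows what such a change does here, so the expectation for this assay rests on compound 2 alone. The step from compound 2 to compound 3 is expected to be a number 0.10 degrees C higher from compound 2 to compound 3 (within the scatter), no larger than the scatter in either direction. Compound 3 is therefore estimated to give 0.9 degrees C, in a range from -0.3 degrees C to 2.3 degrees C.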

Compound 3, shift of the target's melting temperature: 0.8 degrees C
Estimate against measurement, compound 3: 0.10 degrees C above; measured number inside the range.
By their numbers in this assay, from the lowest: compounds 2, 3 and 1 (each within the scatter of the next).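

In this assay, for the compounds shown here, the change from phenyl to 4-methylphenyl gives no change at the digits printed from compound 2 to compound 3 (within the scatter), the first step here that isolates a single change. So a methyl on this aromatic carbon, para to a large group, does not lift the stabilisation of the target out of the low range shared by the two compounds before it; at this position, adding one carbon leaves the read-out as it was. No separate measurement is available that bears on this result.

One methyl is a single small probe, so these compounds leave open whether a different group at the same place, such as an amine, a carboxylic acid or a longer chain, would move the number beyond the scatter. They also leave open whether the same methyl would behave alike on the core of compound 1, which carries a different group across the urea.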